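A few compounds are considered here, and "the series" means these few. Any claim that something is new, unique, unknown or untested is made for them only; others in the source may bear on it.

Measured compounds and their values in a functional assay on MCF7 cells (Homo sapiens) for cytotoxicity, read by MTT assay, with a stated time of 48 h; a lower number here means a stronger inhibitor, a higher number a weaker inhibitor:
compound 1, `O=C(COc1c(F)cc(C(=O)c2ccc(F)cc2)cc1Cl)NNC(=O)c1ccc(=O)oc1`: 63200 nM
compound 2, `Cn1cnc(C(=O)NNC(=O)COc2c(F)cc(C(=O)c3ccc(F)cc3)cc2Cl)c1`: 45100 nM
compound 3, `O=C(COc1ccc(C(=O)c2ccccc2)cc1)NNC(=O)c1ccc(=O)oc1`: 93200 nM

Compound 2 stands closest to compound 1; the step of a 1.4-fold lower number from compound 1 to compound 2 (0.15 log units; within the scatter) lies within the scatter, so the two cannot be ranked. Compound 3 gives a higher number than compound 2, and that gap lies beyond the scatter.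

Compound 4, `Cc1ccc(C(=O)c2cc(F)c(OCC(=O)NNC(=O)c3cn(C)cn3)c(Cl)c2)cc1`, is not yet measured. It differs from compound 2 by methyl in place of fluoro on an aromatic carbon. For the measured compounds named here, no measured step touches this part of the molecule; the only single-point step, a 1.4-fold lower number from compound 1 to compound 2 (0.15 log units; within the scatter), concerns the hydrazide end and stayed within the scatter. Nothing in these data points to a direction, so no step beyond the scatter is expected in this assay. Compound 4 is therefore expected to give 45000 nM, between 20000 nM and 100000 nM. That means an expected step of a 1.0-fold lower number from compound 2 to compound 4 (0.00 log units; within the scatter).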

Compound 4, half-maximal inhibitory concentration: 9800 nM
Beside the measured number, compound 4's estimate is 4.6-fold (0.66 log units) above it; measured number below the stated range.
By their numbers in this assay, from the lowest: compound 4; then compounds 2, 1 and 3 (each within the scatter of the next, the first and the last beyond it).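

In this assay, for the compounds shown here, 4-fluorophenyl going to 4-methylphenyl gives a 4.6-fold lower number from compound 2 to compound 4 (0.66 log units; beyond the scatter), the only step between compounds differing in one place that lies beyond the scatter. The aromatic carbon para to a large group therefore responds to what it carries, even though a single heavy atom changes and no ring, donor or acceptor enters or leaves. Nothing measured here gives a reason for this step.

As far as these compounds go, whether an ethyl chain, a methoxy group or an amine at this carbon would move the number further remains open. So does whether methyl gives a similar step when the hydrazide end of compound 1 is present.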